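Swapping a Carboxylic Acid for a Hydroxyl Chain

A few compounds are considered here, and "the series" means these few. Any claim that something is new, unique, unknown or untested is made for them only; others in the source may bear on it.

Of the compounds shown here, three sharing one core have been tested in a functional assay on HCT-116 cells (Homo sapiens) for antiproliferative activity, read by sulforhodamine B assay, with a stated time of 72 h; on this read-out higher numbers stand for weaker inhibition and lower numbers for stronger inhibition. Compound 1 `COc1ncc(-c2ccc3ncnc(Nc4cnn(CCC(=O)O)c4)c3c2)cc1NS(C)(=O)=O` gives 1290 nM in this assay. Compound 3 `COc1ncc(-c2ccc3ncnc(Nc4cnn(CC(=O)O)c4)c3c2)cc1NS(=O)(=O)c1ccc(F)cc1F` gives 1540 nM in this assay, a number that sits within the usual scatter of the value for compound 1, so the two cannot be told apart. Going by the values given here, compound 2 `CCCCS(=O)(=O)Nc1cc(-c2ccc3ncnc(Nc4ccc(OCCO)nc4)c3c2)cnc1OC` reaches only the limit of the assay, > 20000 nM, and no true number is available for it; this is the single value of the three that stands at the limit of > 20000 nM in this assay, at which 1 of the 3 values shown sits.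

Compound 4 `COc1ncc(-c2ccc3ncnc(Nc4cnn(CCCO)c4)c3c2)cc1NS(=O)(=O)c1ccc(F)cc1F` has not yet been measured. It differs from compound 3 in one place: 2-hydroxyethyl in place of carboxy on a saturated chain carbon bound to an aromatic nitrogen. The acidic group on the chain attached to the pyrazole ring is replaced by a neutral alcohol chain of the same length in heavy atoms. Compound 1 and compound 3 carry the carboxy group with different chain lengths and sulfonamide groups, and their values lie close together; compound 2 carries a hydroxyl chain but differs from compound 3 in several places at once, so it offers no clean comparison.

Among the compounds with values here, with no single-change step available, the expectation for compound 4 is a value of about 1800 nM, between 500 nM and 6000 nM, which would mean an estimated step of a 1.2-fold higher number from compound 3 to compound 4 (0.07 log units; within the scatter), not beyond the scatter.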

Compound 4, half-maximal inhibitory concentration: 480 nM
Estimate against measurement, compound 4: 3.8-fold (0.57 log units) above, outside the stated range (below it).
By their numbers in this assay, from the lowest: compound 4; then compounds 1 and 3 (each within the scatter of the next). At a limit, above all of these: compound 2.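

In this assay, going by these compounds alone, the one change from carboxy to 2-hydroxyethyl on a saturated chain carbon bound to an aromatic nitrogen gives a 3.2-fold lower number from compound 3 to compound 4 (0.51 log units; beyond the scatter), a modest step but one beyond the scatter. Compounds 1 and 3 both carry the carboxy group, so they could not show whether this group is needed for activity; this pair shows that, with the rest of compound 3 unchanged, a chain ending in a hydroxyl keeps the activity and gives a lower number, so the carboxy group is not required here. Within the data shown here, the values shown do not explain why the hydroxyl chain gives the lower number, and the only other information available, about a limit reached by a different compound, has no bearing on this step.

The change can also be read as carboxymethyl to 3-hydroxypropyl, so this single pair cannot separate the effect of the end group from that of the chain itself. Going by these compounds, an amine or a methyl ether at the end of the same chain, or a shorter or longer hydroxyl chain, would help to separate them, and it remains open whether the step carries over to other sulfonamide groups.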